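Swapping the naphthyl ether for a dimethylphenyl ether

The source may report more compounds than this note shows. Statements on the series, on what has been measured and on what is new or still open speak of the compounds shown alone.

Compound 1 `CC(C)C[C@H](N)c1cc(C(F)(F)F)ccc1N1CCN(C(=O)COc2ccc3ccccc3c2)CC1` is the reference here. In an assay on HEK293 cells for displacement of a labelled ligand from Melanocortin receptor 4 (Homo sapiens) (a higher number here means a weaker inhibitor, a lower number a stronger inhibitor), compound 1 gives 2000 nM, the lowest of the two numbers shown. Compound 2 `CC(C)C[C@H](N)c1cc(C(F)(F)F)ccc1N1CCN(C(=O)COc2cccc(Cl)c2Cl)CC1` gives 2500 nM, and the step of a 1.3-fold higher number from compound 1 to compound 2 (0.10 log units; within the scatter) stays within the scatter. Compound 3 `CC(C)C[C@H](N)c1cc(C(F)(F)F)ccc1N1CCN(C(=O)CCC(=O)N(C)C)CC1` gives only a limit, > 10000 nM. The steps of an at least 5.0-fold higher number from compound 1 to compound 3 (0.69 log units; beyond the scatter) and an at least 4.0-fold higher number from compound 2 to compound 3 (0.60 log units; beyond the scatter) show that (dimethylcarbamoyl)methyl in place of either aryloxy group costs binding, as far as the limit of > 10000 nM in this assay, at which 1 of the 3 values shown sits, allows one to say. Compound 4 `Cc1ccc(OCC(=O)N2CCN(c3ccc(C(F)(F)F)cc3[C@@H](N)CC(C)C)CC2)c(C)c1` keeps the aryl ether and alters only the aryl group: 2,4-dimethylphenyl in place of naphthalen-2-yl on an oxygen on a saturated carbon. For the measured compounds named here, the one measured step that bears on such a change, from compound 1 to compound 2, stayed within the scatter. Compound 4 is therefore expected to move little, a 1.3-fold higher number from compound 1 to compound 4 (0.10 log units; within the scatter). Compound 4 is estimated at 2500 nM, within 1000 nM to 6500 nM.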

Compound 4, inhibition constant: 4000 nM
Beside the measured number, compound 4's estimate is 1.6-fold (0.20 log units) below it, within the range that was stated.
By their numbers in this assay, from the lowest: compounds 1, 2 and 4 (each within the scatter of the next). At a limit, above all of these: compound 3.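

The 2,4-dimethylphenyl ether holds its place in this assay with a single aromatic ring in place of two: a 2.0-fold higher number from compound 1 to compound 4 (0.30 log units; within the scatter). It also stays level with the dichlorinated ether, a 1.6-fold higher number from compound 2 to compound 4 (0.20 log units; within the scatter), so three different aryl groups on this oxygen now read alike. Compound 4 also keeps the advantage of the aryl ethers over the amide chain, an at least 2.5-fold lower number from compound 3 to compound 4 (0.39 log units; beyond the scatter), though that step rests on the value of compound 3, which is a limit: the limit of > 10000 nM in this assay, at which 1 of the 4 values shown sits.

Still open, from the compounds shown here alone, is whether the ether oxygen itself is needed, since every aryl group here sits on it. Also open, going by these compounds, is how a pyridine ring or a phenyl ring bearing an amine or a carboxylic acid would fare at this place.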